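The source may hold more compounds than are shown below. What is called first, only, known or untested is meant among the compounds shown, and "the series" means these compounds.

Measured compounds:
compound 1, `CCC(C)C1NC(=O)N(C2CCCC2)C1=O`: > 100000 nM
compound 2, `CCC(C)C(NC(=O)n1nnc2ccccc21)C(=O)NC(c1ccccc1)c1ccccc1`: 60000 nM
compound 3, `CCC(C)C1NC(=O)N(Cc2ccccc2)C1=O`: > 100000 nM

All three were tested in a functional assay on HeLa cells (Homo sapiens) for inhibition; on this read-out higher numbers stand for weaker inhibition and lower numbers for stronger inhibition. For compound 1 the reading > 100000 nM is a limit of the assay, not a number. For compound 3 the reading > 100000 nM is likewise a limit. Compound 2 gives 60000 nM, which is a number. Compound 1 therefore stands at the limit of > 100000 nM in this assay, at which 2 of the 3 values shown sit; nothing beyond that limit is known for it. Going by the values given here, no two of the measured compounds differ in only one place, so no measured step is available.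

The unmeasured compound 4, `O=C1NC(c2ccccc2)C(=O)N1C1CCCC1`, keeps the core of compound 1 with its cyclopentyl group and differs from it by phenyl in place of sec-butyl on a saturated ring carbon. Among the compounds with values here, with only a limit known for compound 1, there is no measured step to guide the size of the change in this assay. The expectation for compound 4 is that it stays near the same limit, with no step beyond the scatter in either direction, so that the expected step is a step that the limit leaves unreadable from compound 1 to compound 4. Compound 4 is estimated at 150000 nM, within a range from 30000 nM to 1000000 nM, and most likely only a limit will be reported for it.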

Compound 4, half-maximal inhibitory concentration: > 100000 nM
Compound 4 gave a limit, no number; the forecaster's own chance of this, stated with the estimate: 75%; the middle value is on the limit's open side.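

In this assay compound 4 gives > 100000 nM, which is a limit and not a number. Compound 1 also gives only a limit, so no step from compound 1 to compound 4 can be read: the limit of > 100000 nM in this assay, at which 3 of the 4 values shown sit.

The compounds shown leave open whether phenyl in place of sec-butyl changes inhibition at all.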